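The compounds below may be only part of what the source reports. "The series", "measured", "known", "first", "only" and "open" are said of these compounds alone.

In an ADME assay on Huh-7 cells (Homo sapiens) for cytotoxicity, read by MTT assay, with a stated time of 96 h (a higher number here means that more compound is tolerated, a lower number that less compound is tolerated), compound 1 `COc1cc(NCc2ccc(C)o2)ccc1-c1cnco1` gives 63400 nM and compound 2 `COc1cc(NCc2ccncc2)ccc1-c1cnco1` gives 72200 nM, so these two stand level. Compound 3 `COc1cc(NCc2cncs2)ccc1-c1cnco1` has 1,3-thiazol-5-yl in place of pyridin-4-yl on a saturated chain carbon bound to a nitrogen on an aromatic ring. Among the compounds with values here, only one measured step bears on this, a change of ring at the same place, and a 1.1-fold higher number from compound 1 to compound 2 (0.06 log units; within the scatter) is small. A similarly small change, within the scatter, is therefore expected, with a 1.2-fold lower number from compound 2 to compound 3 (0.08 log units; within the scatter) as the estimated step. Compound 3 is estimated at 60000 nM, with an expected range of 28000 nM to 100000 nM.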

Compound 3, half-maximal cytotoxic concentration: 68900 nM
For compound 3 the middle estimate is 1.1-fold (0.06 log units) below the measured one; measured number inside the range.
By their numbers in this assay, from the lowest: compounds 1, 3 and 2 (each within the scatter of the next).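

In this assay, the five-membered 1,3-thiazol-5-yl ring, which brings in sulfur, stands level with both earlier rings, with a 1.0-fold lower number from compound 2 to compound 3 (0.02 log units; within the scatter) and a 1.1-fold higher number from compound 1 to compound 3 (0.04 log units; within the scatter) as the steps. At this place, on a saturated chain carbon bound to a nitrogen on an aromatic ring, three different aromatic rings, six-membered and five-membered alike, therefore give numbers that stand level. No measurement is at hand that would explain this reading. From the compounds shown here alone, whether an amine, a carboxylic acid or a longer chain in place of these rings would shift the number stays open, as does whether any ring is needed here at all.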